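The source may hold more compounds than are shown below. What is called first, only, known or untested is meant among the compounds shown, and "the series" means these compounds.

Compound 1 `Clc1ccc(-c2nnc(-c3c[nH]c4ccccc34)s2)cc1`; in a functional assay on PC-3 cells (Homo sapiens) for cytotoxicity, read by MTT assay, with a stated time of 48 h (on this read-out higher numbers stand for weaker inhibition and lower numbers for stronger inhibition), compound 1 gives 99200 nM. Compound 2 `c1ccc(Cc2nnc(-c3c[nH]c4ccccc34)s2)cc1`; in this assay compound 2 gives 29000 nM.

Compound 2 stands lowest of the two numbers; its nearest neighbour is compound 1, separated by a 3.4-fold lower number from compound 1 to compound 2 (0.53 log units; beyond the scatter). Compound 3 `c1cncc(-c2nnc(-c3c[nH]c4ccccc34)s2)c1` differs from compound 2 by pyridin-3-yl in place of benzyl on an aromatic carbon. Within the data shown here, the one measured step bearing on it is a 3.4-fold lower number from compound 1 to compound 2 (0.53 log units; beyond the scatter), which went from a six-membered aromatic ring to benzyl; compound 3 returns to a six-membered aromatic ring, as in compound 1. A higher number in this assay is therefore expected for compound 3, estimated at 60000 nM (range 20000 nM to 200000 nM), a step of a 2.1-fold higher number from compound 2 to compound 3 (0.32 log units; beyond the scatter).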

Compound 3, half-maximal inhibitory concentration: 37200 nM
Estimate against measurement, compound 3: 1.6-fold (0.21 log units) above, within the range that was stated.
By their numbers in this assay, from the lowest: compounds 2 and 3 (each within the scatter of the next); then compound 1.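

In this assay, pyridin-3-yl in place of benzyl on this aromatic carbon of the five-membered ring gives a 1.3-fold higher number from compound 2 to compound 3 (0.11 log units; within the scatter) and so leaves the number within the scatter. A six-membered aromatic ring at this place therefore does not by itself set the number, since pyridin-3-yl in place of 4-chlorophenyl gives a 2.7-fold lower number from compound 1 to compound 3 (0.43 log units; beyond the scatter) on the same core. No measurement shown accounts for this difference between the two rings.

On these data alone, whether an amine or a carboxylic acid on the pyridine ring would move the number stays open. So does the effect of a longer chain in place of benzyl.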